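A few compounds are considered here, and "the series" means these few. Any claim that something is new, unique, unknown or untested is made for them only; others in the source may bear on it.

Three compounds share one core and differ only in the group on one aromatic carbon. Compound 1 `Cc1cc(C)n(-c2ccc(Cl)c(C(=O)NC(=O)Nc3nc4ccc(S(=O)(=O)CCCN5CCN(C)CC5)cc4s3)c2)n1` gives 1.3 nM in an assay on HEK293 cells for displacement of a labelled ligand from growth hormone secretagogue receptor type 1 (Homo sapiens), with a stated time of 60 min; a higher number here means a weaker inhibitor, a lower number a stronger inhibitor. Compound 2 `CN1CCN(CCCS(=O)(=O)c2ccc3nc(NC(=O)NC(=O)c4cc(-n5cccc5)ccc4Cl)sc3c2)CC1` gives 0.15 nM in this assay, after a step of an 8.7-fold lower number from compound 1 to compound 2 (0.94 log units; beyond the scatter). Compound 3 `CCc1ccc(Cl)c(C(=O)NC(=O)Nc2nc3ccc(S(=O)(=O)CCCN4CCN(C)CC4)cc3s2)c1` gives 0.078 nM in this assay, the lowest of the three numbers shown, though the gap to compound 2 lies within the scatter; the steps leading to it are a 17-fold lower number from compound 1 to compound 3 (1.22 log units; beyond the scatter) and a 1.9-fold lower number from compound 2 to compound 3 (0.28 log units; within the scatter). Compound 4 `Cc1ccn(-c2ccc(Cl)c(C(=O)NC(=O)Nc3nc4ccc(S(=O)(=O)CCCN5CCN(C)CC5)cc4s3)c2)n1` has not yet been measured. The change from compound 3 to compound 4 is 3-methyl-1H-pyrazol-1-yl in place of ethyl on an aromatic carbon. The step of a 17-fold lower number from compound 1 to compound 3 (1.22 log units; beyond the scatter) bears most directly on this change, as it exchanges a closely related pyrazolyl ring for ethyl, and a 1.9-fold lower number from compound 2 to compound 3 (0.28 log units; within the scatter) bears on it as well. Restoring a five-membered aromatic ring with 2 hetero atoms in place of ethyl is therefore expected to raise the number, with a step between those two, so a 5.1-fold higher number from compound 3 to compound 4 (0.71 log units; beyond the scatter) is expected. Compound 4 is estimated at 0.4 nM in this assay, within a range of 0.12 nM to 1.5 nM.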

Compound 4, half-maximal inhibitory concentration: 0.53 nM
For compound 4 the middle estimate is 1.3-fold (0.12 log units) below the measured one; measured number inside the range.
By their numbers in this assay, from the lowest: compounds 3 and 2 (each within the scatter of the next); then compound 4; then compound 1.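

On the carbon para to the chloro group, a ring can hold much of the binding seen with ethyl, yet 3-methyl-1H-pyrazol-1-yl still falls short of it in this assay (a 6.8-fold higher number from compound 3 to compound 4 (0.83 log units; beyond the scatter)). The ring's methyl count also matters, as removing one methyl from 3,5-dimethyl-1H-pyrazol-1-yl gives a step beyond the scatter (a 2.5-fold lower number from compound 1 to compound 4 (0.39 log units; beyond the scatter)). The two rings carrying fewer substituents are also separated (a 3.5-fold higher number from compound 2 to compound 4 (0.55 log units; beyond the scatter)), although that step changes a ring nitrogen and a methyl together, so it cannot assign the loss to either.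

The compounds shown leave open whether unsubstituted 1H-pyrazol-1-yl would separate those two changes, and whether a propyl chain or a methoxy group would match ethyl here. No measurement given here explains any of these differences.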